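Sulfonyl aryl changes at the assay limit

The compounds below may be only part of what the source reports. "The series", "measured", "known", "first", "only" and "open" are said of these compounds alone.

Compound 1 `C=Cc1ccc(S(=O)(=O)Nc2ccc3oc(-c4ccccc4)nc3c2)cc1` is the reference point of this small set. In an assay on isolated protein for inhibition of malate dehydrogenase, mitochondrial (Sus scrofa), with stated times of 45 min and 30 min (on this read-out higher numbers stand for weaker inhibition and lower numbers for stronger inhibition), compound 1 gives > 63000 nM, which is a limit of the assay and not a number. Compound 2 `O=S(=O)(Nc1ccc2oc(-c3ccccc3)nc2c1)c1cccs1` carries thiophen-2-yl on the sulfonyl sulfur. In this assay compound 2 gives > 63000 nM, again a limit. Compound 3 `O=S(=O)(Nc1ccc2oc(-c3ccccc3)nc2c1)c1ccccc1O` carries 2-hydroxyphenyl on the sulfonyl sulfur. In this assay compound 3 gives > 63000 nM, also a limit. Because every value sits at the limit of > 63000 nM in this assay, at which 3 of the 3 values shown sit, the steps a step that the two limits leave unreadable from compound 1 to compound 2 and a step that the two limits leave unreadable from compound 1 to compound 3 have no readable size, and the same holds for a step that the two limits leave unreadable from compound 2 to compound 3. Compound 4 `O=S(=O)(Nc1ccc2oc(-c3ccccc3)nc2c1)c1ccc(C(F)(F)F)cc1` differs from compound 1 by trifluoromethyl in place of vinyl on an aromatic carbon. The measured steps that vary the sulfonyl aryl show nothing readable, so no step beyond the scatter can be expected. The expected step is a step that the limit leaves unreadable from compound 1 to compound 4, with no readable direction. Compound 4 is expected to give 100000 nM, with a range from 30000 nM to 400000 nM, most likely again reported as a limit.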

Compound 4, half-maximal inhibitory concentration: > 63000 nM
Compound 4 gave a limit, no number (the forecaster's own chance of this, stated with the estimate: 85%); the middle value is on the limit's open side.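

No new step can be read: the step from compound 1 to compound 4 has no readable size, and the measured values offer no comparison: the limit of > 63000 nM in this assay, at which 4 of the 4 values shown sit. The compounds shown leave open whether any sulfonyl aryl group on the shared core gives measurable inhibition.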